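The source may report more compounds than this note shows. Statements on the series, on what has been measured and on what is new or still open speak of the compounds shown alone.

In a functional assay on KBVIN cells (Homo sapiens) for antiproliferative activity, read by sulforhodamine B assay, with a stated time of 3 days (on this read-out lower numbers stand for an effect already at smaller amounts and higher numbers for an effect only at larger amounts of compound), compound 1 `CCC1=C(O)c2c(oc(-c3ccc(C)cc3)cc2=O)C(CC)(CC)C1=O` gives 0.08 uM with its 4-methylphenyl group. Among the compounds with values here, compound 2 `CCC1=C(O)c2c(oc(-c3cccc(F)c3)cc2=O)C(CC)(CC)C1=O` carries a 3-fluorophenyl group on the same core and gives 3.09 uM as the highest of the two numbers so far. Within the data shown here, only one measured step is available, and it is large and beyond the scatter: a 39-fold higher number from compound 1 to compound 2 (1.59 log units; beyond the scatter) is all there is to go on.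

Compound 3 `CCC1=C(O)c2c(oc(-c3ccc(C)cc3C)cc2=O)C(CC)(CC)C1=O` remains unmeasured. Its change from compound 2 is 2,4-dimethylphenyl in place of 3-fluorophenyl on an aromatic carbon and amounts to 2,4-dimethylphenyl in place of 3-fluorophenyl on an aromatic carbon next to the ring oxygen. The entering group resembles the 4-methylphenyl group of compound 1 with one further methyl group, so a 39-fold higher number from compound 1 to compound 2 (1.59 log units; beyond the scatter) bears on this change when read in reverse. No measurement shows what that further methyl group does. In this assay a clearly lower number is therefore expected, with much but not all of that large step recovered. The expected change is a 10-fold lower number from compound 2 to compound 3 (1.01 log units; beyond the scatter) as an estimate only. Compound 3 is estimated at 0.3 uM with an expected range from 0.06 uM to 1.5 uM for now.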

Compound 3, concentration for half-maximal effect: 8.52 uM
Compound 3: middle estimate off by 28-fold (1.45 log units), on the low side; the measured number lies above the stated range.
By their numbers in this assay, from the lowest: compound 1; then compound 2; then compound 3.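

In this assay the low number of compound 1 does not carry over to a group that merely contains its 4-methylphenyl group: one added methyl group, giving 2,4-dimethylphenyl, produces a 110-fold higher number from compound 1 to compound 3 (2.03 log units; beyond the scatter) and so loses everything that compound 1 had gained over compound 2. That single added methyl group thus weighs at least as heavily here as the full exchange of the aromatic group did in a 39-fold higher number from compound 1 to compound 2 (1.59 log units; beyond the scatter) and leaves this aromatic carbon, next to the ring oxygen, far more demanding about its substituent than the first two compounds could show. Even against the weak 3-fluorophenyl compound, the change gives a 2.8-fold higher number from compound 2 to compound 3 (0.44 log units; beyond the scatter) and places compound 3 highest of the three, so the 4-methylphenyl group alone does not secure a low number, and nothing given here explains these differences.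

The compounds shown do not reveal whether other substituents on this aromatic group, such as a methoxy group, a chlorine atom or an amine, would keep the number near that of compound 1. They also leave open whether a longer chain such as ethyl in place of the methyl group of compound 1 would be tolerated on the shared core.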